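From Methoxy to Cyano in a Growth Inhibition Series

A few compounds are considered here, and "the series" means these few. Any claim that something is new, unique, unknown or untested is made for them only; others in the source may bear on it.

Among the measured compounds shown here, in a functional assay on KB cells (Homo sapiens) for antiproliferative activity, read by sulforhodamine B assay, with a stated time of 48 h (on this read-out higher numbers stand for weaker inhibition of growth and lower numbers for stronger inhibition of growth), compound 1 (`COc1ccc(Nc2nc(NC3CCCC3)c3ccccc3n2)cc1`) gives 11100 nM, the higher of the two numbers measured so far and therefore the weaker inhibition of growth. For the measured compounds named here, the only other measured compound, compound 2 (`CCCNc1nc(Nc2ccc(OC)cc2)nc2ccccc12`), gives 5330 nM. The two are joined by a 2.1-fold lower number from compound 1 to compound 2 (0.32 log units; beyond the scatter), a modest change just beyond the scatter, made by propyl in place of cyclopentyl on a nitrogen on an aromatic ring.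

Compound 3 (`N#Cc1ccc(Nc2nc(NC3CCCC3)c3ccccc3n2)cc1`) keeps the cyclopentyl of compound 1 and differs elsewhere: cyano in place of methoxy on an aromatic carbon. This places cyano in place of methoxy on an aromatic carbon, para to a large group. Going by the values given here, no measured step touches that place. That leaves a 2.1-fold lower number from compound 1 to compound 2 (0.32 log units; beyond the scatter) as a rough guide to size only, and it says nothing about direction. With no evidence pointing either way, no step beyond the scatter is expected in this assay, though the uncertainty is wide. The estimated step is a 1.1-fold higher number from compound 1 to compound 3 (0.03 log units; within the scatter). Compound 3 is expected at 12000 nM, with an estimated range of 4000 nM to 36000 nM.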

Compound 3, concentration for 50% growth inhibition: > 31300 nM
Compound 3: a limit, no number; the forecaster's own chance of this, stated with the estimate: 10%; at least 2.6-fold (0.41 log units) between middle value and limit.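

With the cyclopentyl kept, cyano in place of methoxy on an aromatic carbon, para to a large group, gives an at least 2.8-fold higher number from compound 1 to compound 3 (0.45 log units; beyond the scatter). Among the compounds shown here, this is the first measured evidence that the group at this place matters in this assay, and here the change from 4-methoxyphenyl to 4-cyanophenyl goes toward weaker inhibition of growth, a direction the earlier step on the nitrogen could not indicate. For compound 3, > 31300 nM is a limit of the assay and not a number, so the step has a known lower bound but no known full size, and the reading rests on a single limit: the limit of > 31300 nM in this assay, at which 1 of the 3 values shown sits.

The compounds shown leave open whether the same change would read alike with propyl on the nitrogen, as in compound 2, which carries the methoxy. They also leave open how other groups at this place would read, such as a fluorine, a hydroxyl or an amine, and so whether the methoxy itself contributes to growth inhibition or the cyano alone takes it away.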